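The source may report more compounds than this note shows. Statements on the series, on what has been measured and on what is new or still open speak of the compounds shown alone.

Measured compounds:
- compound 1, `CCCCc1nc(C(C)C)c(CC(=O)OC)c(=O)n1Cc1ccc(-c2ccccc2-c2noc(=O)[nH]2)cc1`, in an ADME assay on microsomes from liver (Mus musculus) for metabolic stability, with a stated time of 30 min (on this read-out higher numbers stand for a more stable compound and lower numbers for a less stable compound), gives 9.4%
- compound 2, `CCCCc1nc(C(C)C)c(CC(=O)OCC(F)(F)F)c(=O)n1Cc1ccc(-c2ccccc2-c2noc(=O)[nH]2)cc1`, in this assay gives "not determined" (no result reported)
- compound 3, `CCCCOC(=O)Cc1c(C(C)C)nc(CCCC)n(Cc2ccc(-c3ccccc3-c3noc(=O)[nH]3)cc2)c1=O`, in this assay gives 21.6%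

Compound 2 shares the core of compound 1 but carries a 2,2,2-trifluoroethyl ester; for compound 2 no result in this assay was reported, so it stands without a number. Compound 4, `CCCCc1nc(C(C)C)c(CC(=O)OC2CC2)c(=O)n1Cc1ccc(-c2ccccc2-c2noc(=O)[nH]2)cc1`, differs from compound 2 in one place: cyclopropyl in place of 2,2,2-trifluoroethyl on an oxygen next to a carbonyl group. Going by the values given here, the only measured step that touches the same position is a number 12.2 percentage points higher from compound 1 to compound 3 (beyond the scatter), where the ester alkyl was lengthened and stability rose modestly. That step shows that the group on the ester oxygen can move the read-out by a modest amount in this series, but it covers a different pair of groups, and compound 2 itself has no value to start from. A cyclopropyl group is closer in size to methyl than to butyl, so the number for compound 4 is expected to fall between those two measured points, with wide uncertainty. Compound 4 is therefore expected to give 16%, with a range from 5% to 40%.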

Compound 4, percent of the compound remaining: 11.4%
Compound 4: middle estimate off by 4.6 percentage points, on the high side, and the stated range covers the measured number.
By their numbers in this assay, from the lowest: compounds 1 and 4 (each within the scatter of the next); then compound 3.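

On the ester oxygen, in this assay, cyclopropyl and methyl cannot be told apart, with a number 2 percentage points higher from compound 1 to compound 4 (within the scatter), while cyclopropyl in place of butyl gives a number 10.2 percentage points lower from compound 3 to compound 4 (beyond the scatter), so the butyl ester of compound 3 is the only one of these three esters that stands apart from the others. The change from 2,2,2-trifluoroethyl to cyclopropyl itself cannot be read, as compound 2 has no number to compare with. No measurement shown here gives a reason for these differences.

Going by these compounds, whether the read-out climbs steadily with chain length stays open, and an ethyl, propyl or hexyl ester on the shared core would speak to that. On these data alone, how a free carboxylic acid in place of the ester would read also stays open.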